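Piperazine dithiocarbamate benzamides: pyridyl nitrogen shift

This account rests on a few compounds, and the source may have more. Where it says the series, first, only, none or still open, it means among the compounds named here.

Compound 3 `Nc1ccccc1NC(=O)c1ccc(CSC(=S)N2CCN(c3ccncc3)CC2)cc1` gives 77.4% in a functional assay on HeLa cells (Homo sapiens) for antiproliferative activity, read by CCK-8 assay, with a stated time of 72 h, tested at 8 uM (a higher number here means a stronger effect of the compound at the concentration tested, a lower number a weaker effect), the highest number of the three measured, though compound 1 `Nc1ccccc1NC(=O)c1ccc(CSC(=S)N2CCN(Cc3ccncc3)CC2)cc1` with 72.9% sits within the scatter of it; only compound 2 `COc1ccc(N2CCN(C(=S)SCc3ccc(C(=O)Nc4ccccc4N)cc3)CC2)cc1` with 52.3% lies clearly lower. The shown steps are a number 4.5 percentage points higher from compound 1 to compound 3 (within the scatter) and a number 25.1 percentage points higher from compound 2 to compound 3 (beyond the scatter), with a number 20.6 percentage points lower from compound 1 to compound 2 (beyond the scatter) between the other two.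

Compound 4 `Nc1ccccc1NC(=O)c1ccc(CSC(=S)N2CCN(c3cccnc3)CC2)cc1` differs from compound 3 by pyridin-3-yl in place of pyridin-4-yl on an amine nitrogen in a ring. For the measured compounds named here, none of the measured steps moves the nitrogen within the aromatic ring; the nearest comparison is the step from compound 1 to compound 3, where exchanging a directly attached pyridin-4-yl for its methylene-linked form stayed within the scatter, and the only step beyond the scatter, from compound 2 to compound 3, removed a 4-methoxyphenyl entirely. The expectation is therefore a step of a number 3.4 percentage points lower from compound 3 to compound 4 (within the scatter), no change beyond the scatter in this assay.

For compound 4 the expected value in this assay is 74%, estimated to fall between 58% and 86%.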

Compound 4, a percentage reported as inhibition, at one concentration (the size of the read-out at that concentration, not a potency): 72.5%
Compound 4: middle estimate off by 1.5 percentage points, on the high side, and the stated range covers the measured number.
By their numbers in this assay, from the lowest: compound 2; then compounds 4, 1 and 3 (each within the scatter of the next).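

Moving the ring nitrogen from pyridin-4-yl to pyridin-3-yl at this position is the first change of its kind in the series, and in this assay it gives a number 4.9 percentage points lower from compound 3 to compound 4 (within the scatter), so this assay does not separate the two pyridine isomers. The pyridin-3-yl form also shows a number 0.4 percentage points lower from compound 1 to compound 4 (within the scatter) and a number 20.2 percentage points higher from compound 2 to compound 4 (beyond the scatter), so the gap to the 4-methoxyphenyl form now holds for both directly attached pyridines and for the methylene-linked one. No measured evidence accounts for compounds 1, 3 and 4 all standing clear of compound 2.

As far as these compounds go, whether pyridin-2-yl on this ring nitrogen would stay with the other pyridines remains open, as does whether an unsubstituted phenyl would group with them or with compound 2. A read-out at one concentration also leaves open whether compounds 1, 3 and 4 would show a stronger or weaker effect than one another at other concentrations.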